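Swapping the amide-side aryl group of compound 3

The source may report more compounds than this note shows. Statements on the series, on what has been measured and on what is new or still open speak of the compounds shown alone.

The three measured ureas share one core and differ in the two aryl groups at either end. Compound 1 `COc1cc(NC(=O)Nc2cc(Nc3cc(Br)ccc3OC)ncn2)cc(OC)c1` gives 76.3% in a functional assay on HCC827 cells (Homo sapiens) for inhibition, read by MTT assay, with a stated time of 48 h, tested at 10 uM; a higher number here means more inhibition at the concentration tested (going by the name of the read-out), a lower number less inhibition. Compound 2 `CCc1cccc(Nc2cc(NC(=O)Nc3cc(OC)cc(OC)c3)ncn2)c1` gives 52.6% in this assay. Compound 3 `CC(C)(C)c1ccc(Nc2cc(NC(=O)Nc3c(Cl)cccc3Cl)ncn2)cc1` gives 42.3% in this assay, the lowest of the three numbers, with compound 2 nearest and compound 1 furthest from it, both gaps beyond the scatter.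

Compound 4 `COc1cc(NC(=O)Nc2cc(Nc3ccc(C(C)(C)C)cc3)ncn2)cc(OC)c1` is compound 3 with one group exchanged: 3,5-dimethoxyphenyl in place of 2,6-dichlorophenyl on an amide-type nitrogen. Among the measured compounds shown here, the only measured step, a number 23.7 percentage points lower from compound 1 to compound 2 (beyond the scatter), changes the other aryl group, on a nitrogen on an aromatic ring, and so does not bear directly on this exchange. What the numbers do show is that compounds 1 and 2, which both carry a 3,5-dimethoxyphenyl on the amide-type nitrogen, sit above compound 3, which carries the 2,6-dichlorophenyl there, though each pair also differs elsewhere. On that basis a rise beyond the scatter is expected for compound 4, estimated as a number 13.7 percentage points higher from compound 3 to compound 4 (beyond the scatter) in this assay. Compound 4 is therefore expected to give about 56% in this assay, within a range from 36% to 76%.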

Compound 4, a percentage reported as inhibition, at one concentration (the size of the read-out at that concentration, not a potency): 32.7%
Compound 4: middle estimate off by 23.3 percentage points, on the high side, and the stated range ends above it.
By their numbers in this assay, from the lowest: compounds 4 and 3 (each within the scatter of the next); then compound 2; then compound 1.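

At the amide-type nitrogen, 3,5-dimethoxyphenyl in place of 2,6-dichlorophenyl gives a number 9.6 percentage points lower from compound 3 to compound 4 (within the scatter) in this assay, so with 4-(tert-butyl)phenyl on the nitrogen on an aromatic ring, this exchange does not separate the two compounds beyond the usual scatter. With 3,5-dimethoxyphenyl held constant on the amide-type nitrogen, the other aryl group makes a clear difference: 4-(tert-butyl)phenyl in place of 3-ethylphenyl gives a number 19.9 percentage points lower from compound 2 to compound 4 (beyond the scatter), and 4-(tert-butyl)phenyl in place of 5-bromo-2-methoxyphenyl gives a number 43.6 percentage points lower from compound 1 to compound 4 (beyond the scatter). No measurement shown here accounts for either the flat exchange or these larger steps.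

The compounds shown leave open whether 2,6-dichlorophenyl and 3,5-dimethoxyphenyl would also stay within the scatter of each other with 5-bromo-2-methoxyphenyl or 3-ethylphenyl on the nitrogen on an aromatic ring. They also leave open what an aryl group carrying a morpholine, an amine or a carboxylic acid would give on the amide-type nitrogen in this assay.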